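Alkyne chain swap from compound 3 to compound 4

The source may hold more compounds than are shown below. What is called first, only, known or untested is meant among the compounds shown, and "the series" means these compounds.

Three compounds share one core and differ only in the group on a saturated chain carbon bound to a triple-bonded carbon: compound 1 `CCCN(CC#Cc1cc2ncnc(Nc3ccc(OCc4cccc(F)c4)c(Cl)c3)c2s1)CCC`, compound 2 `Fc1cccc(COc2ccc(Nc3ncnc4cc(C#CCN5CCNCC5)sc34)cc2Cl)c1` and compound 3 `COCC#Cc1cc2ncnc(Nc3ccc(OCc4cccc(F)c4)c(Cl)c3)c2s1`. Going by the values given here, in an ADME assay on HepG2 cells (Homo sapiens) for cytotoxicity (on this read-out higher numbers stand for lower toxicity in this test and lower numbers for higher toxicity in this test), compound 1 gives 26.5 uM, the only true number so far. Compound 2 reads > 29 uM, which is a limit of the assay. Compound 3 reads > 33 uM, which is also a limit, so its standing is known only as a limit.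

Compound 4 `CC(C)CC#Cc1cc2ncnc(Nc3ccc(OCc4cccc(F)c4)c(Cl)c3)c2s1` follows from compound 3 by isopropyl in place of methoxy on a saturated chain carbon bound to a triple-bonded carbon, with isopropyl in place of methoxy. Among the compounds with values here, no measured step covers this exchange directly, so the nearest evidence comes from other exchanges at the same place. Methoxy in place of dipropylamino gives an at least 1.2-fold higher number from compound 1 to compound 3 (0.09 log units; that floor lies within the scatter). Piperazin-1-yl in place of dipropylamino gives an at least 1.0-fold higher number from compound 1 to compound 2 (0.03 log units; that floor lies within the scatter). Methoxy in place of piperazin-1-yl gives a step that the two limits leave unreadable from compound 2 to compound 3. Both readable floors lie within the scatter, so no step beyond the scatter is expected in this assay, in either direction. The expected step is an at least 1.1-fold lower number from compound 3 to compound 4 (0.04 log units; that floor lies within the scatter). The lower side of the range rests on compound 1 at 26.5 uM. For compound 4 the estimated value is 30 uM, with an expected range from 14 uM to 55 uM.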

Compound 4, half-maximal toxic concentration: > 32 uM
Compound 4 gave a limit, no number; the forecaster's own chance of this, stated with the estimate: 50%; at least 1.0-fold (0.02 log units) between middle value and limit.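

Isopropyl, with no hydrogen-bond acceptor, is the first group at this place on a saturated chain carbon bound to a triple-bonded carbon that holds only carbon, and in this assay compound 4 reads as a limit of the assay, not a number: the limit of > 32 uM in this assay, at which 1 of the 4 values shown sits. Among the groups shown, an oxygen or a nitrogen attached to this chain carbon is therefore not needed for a reading that ends at a limit. Isopropyl in place of dipropylamino gives an at least 1.2-fold higher number from compound 1 to compound 4 (0.08 log units; that floor lies within the scatter), and the steps from compound 2 to compound 4 and from compound 3 to compound 4 cannot be read, as each joins two limits.

From the compounds shown here alone, only compound 1 has a true number, 26.5 uM, so the order among methoxy, piperazin-1-yl and isopropyl stays open, as does the question of whether any of the three differs from dipropylamino by more than the scatter. Also open, going by these compounds, is how a carboxylic acid or a longer carbon chain at this place would read in this assay, and whether either would give a true number.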